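One more methoxy on a compound at the limit

A few compounds are considered here, and "the series" means these few. Any claim that something is new, unique, unknown or untested is made for them only; others in the source may bear on it.

Measured so far in an ADME assay on THP-1 cells (Homo sapiens) for cytotoxicity, read by MTT assay; on this read-out higher numbers stand for lower toxicity in this test and lower numbers for higher toxicity in this test:
compound 1 `COc1cc(O)c(C(=O)/C=C/c2cc(OC)c(OC)c(OC)c2)cc1OC` gives > 25000 nM as a limit
compound 2 `COc1ccc(C(=O)/C=C/c2ccc(OC)c(OC)c2)c(O)c1` gives > 100000 nM as a limit
compound 3 `COc1ccc(C(=O)/C=C/c2c(OC)cccc2OC)c(O)c1` gives > 100000 nM as a limit

Compound 2 gives no number and stands at the limit of > 100000 nM in this assay, at which 2 of the 3 values shown sit, along with compound 3. Compound 1 stands at the limit of > 25000 nM in this assay, at which 1 of the 3 values shown sits, as its own limit. Compound 4 `COc1ccc(C(=O)/C=C/c2cc(OC)c(OC)c(OC)c2)c(O)c1` is still unmeasured and carries methoxy in place of hydrogen on an aromatic carbon of compound 2 methoxy in place of hydrogen on an aromatic carbon as its only difference. Among the measured compounds shown here, with no measured step to go by, no shift beyond the usual scatter is expected in this assay in either direction. The expected change is a number no higher from compound 2 to compound 4 (the limit leaves the size open) as estimated here. This expectation rests on compound 2 with its limit > 100000 nM and on no number. For compound 4 the estimated value is 100000 nM with an expected range of 40000 nM to 250000 nM in this estimate.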

Compound 4, half-maximal cytotoxic concentration in the THP-1 assay: > 100000 nM
Compound 4: a limit, no number (the forecaster's own chance of this, stated with the estimate: 80%); the middle value sits exactly at the limit.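

In the THP-1 assay compound 1 gives > 25000 nM, which is a limit. In the THP-1 assay compound 2 gives > 100000 nM, which is a limit. In the THP-1 assay compound 4 gives > 100000 nM, which is a limit. Among the compounds shown here, with all three given as limits, neither the step from compound 2 to compound 4 nor the one from compound 1 to compound 4 can be read. The compounds shown leave open whether methoxy in place of hydrogen on an aromatic carbon shifts this read-out at all. In a physicochemical assay for lipophilicity (on this read-out higher numbers stand for higher lipophilicity and lower numbers for lower lipophilicity), compound 2 gives 3.53 and compound 4 gives 3.49, two values within the scatter of each other.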